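Swapping the Pyrazole on Compound 3 for a Methoxypyridine

The source may report more compounds than this note shows. Statements on the series, on what has been measured and on what is new or still open speak of the compounds shown alone.

Measured so far:
compound 1 `COCC#Cc1cc(C(O)(C(F)(F)F)C(F)(F)F)cnc1N1CCN(S(=O)(=O)c2ccc(N)nc2)CC1` gives 399 mL.min-1.g-1
compound 2 `CCn1cc(-c2cc(C(O)(C(F)(F)F)C(F)(F)F)cnc2N2CCN(S(=O)(=O)c3ccc(N)nc3)CC2)cn1` gives 194 mL.min-1.g-1
compound 3 `CC(C)(C)n1cc(-c2cc(C(O)(C(F)(F)F)C(F)(F)F)cnc2N2CCN(S(=O)(=O)c3ccc(N)nc3)CC2)cn1` gives 459 mL.min-1.g-1

These values come from an ADME assay (liver) for metabolic stability, with Liver microsome (Rattus norvegicus) as the target, using microsomes and NADPH, with a stated time of 30 min, tested at 1 uM; a lower number here means slower removal, a higher number faster removal of the compound. Compound 3 stands highest of the three numbers: its gap to compound 1 is within the scatter, whereas the step of a 2.4-fold higher number from compound 2 to compound 3 (0.37 log units; beyond the scatter) lies beyond it, so only compound 2 is clearly lower.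

Compound 4 `COc1cncc(-c2cc(C(O)(C(F)(F)F)C(F)(F)F)cnc2N2CCN(S(=O)(=O)c3ccc(N)nc3)CC2)c1` is not yet measured. It differs from compound 3 as follows: 5-methoxypyridin-3-yl in place of 1-(tert-butyl)-1H-pyrazol-4-yl on an aromatic carbon.

Within the data shown here, no measured step replaces a pyrazole with a pyridine, so the bearing is indirect. The step of a 1.2-fold higher number from compound 1 to compound 3 (0.06 log units; within the scatter) shows that changing the group at this position can leave the number where it is, while a 2.4-fold higher number from compound 2 to compound 3 (0.37 log units; beyond the scatter) shows that a smaller substituent on the same pyrazole gave a modest fall. With only three points, the change to compound 4 is expected to land between these outcomes: a modest drop or none beyond the scatter.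

For compound 4 the estimate is 240 mL.min-1.g-1, with a range from 110 mL.min-1.g-1 to 480 mL.min-1.g-1, meaning an expected step of a 1.9-fold lower number from compound 3 to compound 4 (0.28 log units; within the scatter).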

Compound 4, intrinsic clearance in microsomes: 58 mL.min-1.g-1
Beside the measured number, compound 4's estimate is 4.1-fold (0.62 log units) above it; measured number outside the range, below it.
By their numbers in this assay, from the lowest: compound 4; then compound 2; then compounds 1 and 3 (each within the scatter of the next).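

In this assay, among these compounds, the change to 5-methoxypyridin-3-yl gives a 7.9-fold lower number from compound 3 to compound 4 (0.90 log units; beyond the scatter), a larger step than any among the earlier compounds. The fall is not tied to the loss of the tert-butyl group alone: the new group also gives a 3.3-fold lower number from compound 2 to compound 4 (0.52 log units; beyond the scatter) and a 6.9-fold lower number from compound 1 to compound 4 (0.84 log units; beyond the scatter), both beyond the scatter, so it stands clear of all three earlier groups at this position. No measurement shown here gives a reason for the fall.

The compounds shown leave open whether the six-membered ring or its methoxy group matters more, as the two enter together. An unsubstituted pyridin-3-yl group would help separate them, and a pyridine carrying an amine or a longer ether chain would show how much the substituent can vary.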